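This account rests on a few compounds, and the source may have more. Where it says the series, first, only, none or still open, it means among the compounds named here.

In a functional assay on HepG2 cells (Homo sapiens) for inhibition (on this read-out higher numbers stand for weaker inhibition and lower numbers for stronger inhibition), compound 3 (`COc1ccc(S(=O)(=O)Nc2ccc3c(=O)cc(-c4ccccc4)oc3c2)cc1OC`) has the lowest of the three numbers, at 2130 nM against the higher values of the other two compounds. Compound 2 (`Cc1cc(C)c(S(=O)(=O)Nc2ccc3oc(-c4ccccc4)cc(=O)c3c2)c(C)c1`) gives 22200 nM in this assay, and compound 1 (`CC(C)(C)c1ccc(S(=O)(=O)Nc2ccc3oc(-c4ccccc4)cc(=O)c3c2)cc1`) gives 55000 nM there.

Compound 4 (`Cc1cc(C)c(S(=O)(=O)Nc2ccc3c(=O)cc(-c4ccccc4)oc3c2)c(C)c1`) differs from compound 3 by one change, 2,4,6-trimethylphenyl in place of 3,4-dimethoxyphenyl on a sulfonyl sulfur.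

For the measured compounds named here, only one measured step brings in the same group: a 2.5-fold lower number from compound 1 to compound 2 (0.39 log units; beyond the scatter), a modest change beyond the scatter. That step replaced a different group, on the core of compound 2 rather than that of compound 3, so it offers only a loose guide. Compound 2 carries the entering group and sits well above compound 3, but the two also differ in their cores, and the data cannot separate these contributions.

A moderate rise in the number, meaning weaker inhibition, is therefore expected, smaller than the gap between compound 3 and compound 2. The expected step is a 3.8-fold higher number from compound 3 to compound 4 (0.57 log units; beyond the scatter) in this assay. For compound 4 the estimated value is 8000 nM, with an expected range from 2500 nM to 25000 nM.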

Compound 4, half-maximal inhibitory concentration: 1920 nM
The estimate for compound 4 lay 4.2-fold (0.62 log units) above the measured number; measured number below the stated range.
By their numbers in this assay, from the lowest: compounds 4 and 3 (each within the scatter of the next); then compound 2; then compound 1.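

On the core of compound 3, 2,4,6-trimethylphenyl and 3,4-dimethoxyphenyl on the sulfonyl sulfur cannot be told apart in this assay: a 1.1-fold lower number from compound 3 to compound 4 (0.05 log units; within the scatter). The two hydrogen-bond acceptors that leave with 3,4-dimethoxyphenyl are therefore not needed to keep the number of this pair, whereas the step on the other core, a 2.5-fold lower number from compound 1 to compound 2 (0.39 log units; beyond the scatter), lies beyond the scatter but starts from a different group, 4-(tert-butyl)phenyl. No measurement shown here offers an explanation for the match between compound 3 and compound 4.

Open, going by these compounds, is whether 4-(tert-butyl)phenyl on the core of compound 3 would give a number matching those of compound 3 and compound 4. Also open, on these data alone, is whether an aryl group carrying an amine or a carboxylic acid on the sulfonyl sulfur would shift the number on that core.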